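The compounds below may be only part of what the source reports. "The series", "measured", "known", "first", "only" and "open" are said of these compounds alone.

Measured so far, in a functional assay on A549 cells (Homo sapiens) for cytotoxicity, read by MTT assay, with a stated time of 72 h; on this read-out lower numbers stand for stronger inhibition and higher numbers for weaker inhibition:
Compound 1 `COc1ncc(-c2ccc3nc(NC(=O)NC4CC4)nn3c2)cc1NS(=O)(=O)c1ccc(F)cc1` gives 210 nM.
Compound 2 `CNC(=O)Nc1nc2ccc(-c3cnc(OC)c(NS(=O)(=O)c4ccc(F)cc4)c3)cn2n1` gives 230 nM.

Compound 2 stands at the higher of the two numbers, with compound 1 nearest; the step of a 1.1-fold higher number from compound 1 to compound 2 (0.04 log units; within the scatter) lies within the scatter. Compound 3 `COc1ncc(-c2ccc3nc(NC(=O)NCCN(C)C)nn3c2)cc1NS(=O)(=O)c1ccc(F)cc1` differs from compound 2 by (dimethylamino)methyl in place of hydrogen on a saturated chain carbon bound to an amide-type nitrogen. Among the measured compounds shown here, the only measured step, a 1.1-fold higher number from compound 1 to compound 2 (0.04 log units; within the scatter), also alters the group on the amide-type nitrogen and produced no change beyond the scatter, so a similar outcome is expected here, with the step of a 1.1-fold higher number from compound 2 to compound 3 (0.04 log units; within the scatter) expected to stay within the scatter. Compound 3 is therefore estimated at 250 nM, in a range from 100 nM to 600 nM.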

Compound 3, half-maximal inhibitory concentration: 800 nM
Compound 3: middle estimate off by 3.2-fold (0.51 log units), on the low side, outside the stated range (above it).
By their numbers in this assay, from the lowest: compounds 1 and 2 (each within the scatter of the next); then compound 3.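

Unlike the swap of cyclopropyl for methyl, this change on the amide-type nitrogen does register in this assay: adding (dimethylamino)methyl gives a 3.5-fold higher number from compound 2 to compound 3 (0.54 log units; beyond the scatter), and 2-(dimethylamino)ethyl in place of cyclopropyl gives a 3.8-fold higher number from compound 1 to compound 3 (0.58 log units; beyond the scatter). Both steps are modest, but they show that this position does not accept every group equally. No measurement here explains the weaker inhibition. Still open, on these data alone, is whether the chain length or the dimethylamino group matters more; a plain propyl chain or a 2-methoxyethyl group on the same nitrogen would help separate the two.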